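The source may hold more compounds than are shown below. What is called first, only, known or untested is meant among the compounds shown, and "the series" means these compounds.

The series shares one core, a sulfonamide carrying an ethylphenyl group and an isobutyl chain, and differs only in the saturated ring that is fused to the aromatic part. Compound 1 `CCc1ccc(N(CC(C)C)S(=O)(=O)c2ccc3c(c2)C(=O)CC(C(C)C2CCOCC2)O3)cc1` carries a carbonyl on that ring and a 1-(oxan-4-yl)ethyl group on the carbon next to the ring oxygen. In a physicochemical assay for lipophilicity, at pH 7.4 (on this read-out higher numbers stand for higher lipophilicity and lower numbers for lower lipophilicity), compound 1 gives 4.93. Compound 2 `CCc1ccc(N(CC(C)C)S(=O)(=O)c2ccc3c(c2)C(F)CC(C2CCOCC2)O3)cc1`, with a fluorine in place of the carbonyl, gives 5.02 in this assay, a number within the scatter of compound 1. Compound 3 `CCc1ccc(N(CC(C)C)S(=O)(=O)c2ccc3oc(C4CCOCC4)cc(=O)c3c2)cc1`, whose fused ring is unsaturated, gives 4.5 in this assay, which lies beyond the scatter below compound 1. Compound 1 thus stands second highest of the three numbers.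

Compound 4 `CCc1ccc(N(CC(C)C)S(=O)(=O)c2ccc3c(c2)C(=O)CC(C2CCOCC2)O3)cc1` differs from compound 1 in one place: oxan-4-yl in place of 1-(oxan-4-yl)ethyl on a saturated ring carbon. Among the measured compounds shown here, no measured pair shows this exact change, so its size must be judged from the groups alone. Since the group that leaves is larger by two carbons than the one that enters, the value in this assay is expected to fall, and the step of a number 0.73 log units lower from compound 1 to compound 4 (beyond the scatter) is expected to lie beyond the scatter. For compound 4 the estimate in this assay is 4.2, with a range from 3.7 to 4.7.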

Compound 4, distribution coefficient: 4.21
The estimate for compound 4 lay 0.01 log units below the measured number; low and high end bracket the measured number.
By their numbers in this assay, from the lowest: compounds 4 and 3 (each within the scatter of the next); then compounds 1 and 2 (each within the scatter of the next).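

In this assay, among the compounds shown here, oxan-4-yl in place of 1-(oxan-4-yl)ethyl on a saturated ring carbon, next to the ring oxygen, gives a number 0.72 log units lower from compound 1 to compound 4 (beyond the scatter), and this is the first step read from two compounds that differ in one place. The two groups share the same six-membered non-aromatic ring with 1 hetero atom and the same counts of hydrogen-bond donors and acceptors, so what separates them is the count of heavy atoms, 8 against 6, and this difference alone goes with a step beyond the scatter. No measurement shown here accounts for the size of this step.

As far as these compounds go, this single step was read only with the carbonyl on the fused ring, so it remains open whether the same exchange would give a step of similar size with fluorine there, where compound 2 gives 5.02 and compound 4 gives 4.21. From the compounds shown here alone, it also remains open how the number would respond to a longer chain or an amine on the same saturated ring carbon.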